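Chain growth on the nitrogen substituent of compound 2

The compounds below may be only part of what the source reports. "The series", "measured", "known", "first", "only" and "open" are said of these compounds alone.

Measured so far in a functional assay (trachea) with Cavia porcellus as the target; on this read-out higher numbers stand for weaker inhibition and lower numbers for stronger inhibition:
compound 1 `Cn1nc(-c2cccnc2)c2ccccc2c1=O`, 11500 nM
compound 2 `CCn1nc(-c2cccnc2)c2ccccc2c1=O`, 1320 nM
compound 3 `CCOC(=O)Cn1nc(-c2cccnc2)c2ccccc2c1=O`, 43700 nM

Compound 2 stands at the lowest number of the three in this assay, with compound 1 and compound 3 both clearly above it. The measured steps all concern the same saturated chain carbon bound to the aromatic nitrogen: an 8.7-fold lower number from compound 1 to compound 2 (0.94 log units; beyond the scatter), whereas a 3.8-fold higher number from compound 1 to compound 3 (0.58 log units; beyond the scatter) and a 33-fold higher number from compound 2 to compound 3 (1.52 log units; beyond the scatter). Compound 4 `O=c1c2ccccc2c(-c2cccnc2)nn1CCCCSc1ncccn1` differs from compound 2 by 2-((pyrimidin-2-yl)sulfanyl)ethyl in place of hydrogen on a saturated chain carbon, two bonds along the chain from an aromatic nitrogen. For the measured compounds named here, no measured step covers a substituent of this kind, so the two precedents point in opposite directions. A step of either sign is possible; the expectation is a 1.3-fold lower number from compound 2 to compound 4 (0.12 log units; within the scatter), placing compound 4 near compound 2. Compound 4 is estimated at 1000 nM, within 150 nM to 7000 nM.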

Compound 4, half-maximal inhibitory concentration: 6170 nM
Beside the measured number, compound 4's estimate is 6.2-fold (0.79 log units) below it, within the range that was stated.
By their numbers in this assay, from the lowest: compound 2; then compounds 4 and 1 (each within the scatter of the next); then compound 3.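

In this assay, a 4.7-fold higher number from compound 2 to compound 4 (0.67 log units; beyond the scatter), so the gain seen on going to the ethyl of compound 2 does not carry over to the 2-((pyrimidin-2-yl)sulfanyl)ethyl group at this position. Compound 3 and compound 4 both stand above compound 2, so neither of the two larger substituents shown improves on it, although the group in compound 4 contains no ester. No evidence at hand explains this step.

The compounds shown do not separate the contributions of the chain, the sulfur and the pyrimidine ring. A plain butyl chain or a chain ending in a dimethylamino group would test whether chain length alone carries the change.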